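A few compounds are considered here, and "the series" means these few. Any claim that something is new, unique, unknown or untested is made for them only; others in the source may bear on it.

The compounds share one core and differ in the group on an aromatic nitrogen. In a functional assay on SH-SY5Y cells (Homo sapiens) for cytotoxicity, read by MTT assay, with a stated time of 72 h (a higher number here means a weaker inhibitor, a lower number a stronger inhibitor), compound 1 (`O=C1c2c[n+]([O-])c3ccccc3c2C(=O)c2c1c1ccccc1n2Cc1cn([C@H]2O[C@H](CO)[C@@H](O)[C@H]2O)nn1`) gives 1340 nM and compound 2 (`O=C1c2c[n+]([O-])c3ccccc3c2C(=O)c2c1c1ccccc1n2Cc1cn([C@@H]2C[C@H](O)[C@@H](CO)O2)nn1`) gives 150 nM. Compound 3 (`O=C1c2c[n+]([O-])c3ccccc3c2C(=O)c2c1c1ccccc1n2Cc1cn(C[C@H](O)CO)nn1`) gives > 1000 nM, which is a limit of the assay and not a number. Compound 3 therefore has no exact place on the scale. The data show an at least 6.6-fold higher number from compound 2 to compound 3 (0.82 log units; beyond the scatter), and also a step that the limit leaves unreadable from compound 1 to compound 3.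

Compound 4 (`CC1(C)OCC(Cn2cc(Cn3c4c(c5ccccc53)C(=O)c3c[n+]([O-])c5ccccc5c3C4=O)nn2)O1`) has not yet been measured. Its difference from compound 3 is 2,2-dimethyl-1,3-dioxolan-4-yl in place of 1,2-dihydroxyethyl on a saturated chain carbon bound to an aromatic nitrogen. In words, 2,2-dimethyl-1,3-dioxolan-4-yl stands in place of 1,2-dihydroxyethyl on a saturated chain carbon bound to an aromatic nitrogen.

Among the compounds with values here, no measured step makes this exact change. The closest guide is an 8.9-fold lower number from compound 1 to compound 2 (0.95 log units; beyond the scatter), where hydrogen replaces hydroxy on a saturated ring carbon, and that step is modest. The step to compound 3 from compound 2 warns against a firm reading, since it runs towards a higher number. A modest move towards a lower number is therefore expected, though with wide uncertainty, and the estimated step is an at least 1.6-fold lower number from compound 3 to compound 4 (0.22 log units; that floor lies within the scatter). In this assay, compound 4 is expected at 600 nM, with an estimated range of 150 nM to 2000 nM.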

Compound 4, half-maximal inhibitory concentration: 230 nM
Compound 4: the middle estimate sits 2.6-fold (0.42 log units) above what was measured; the range from low to high includes it.
By their numbers in this assay, from the lowest: compounds 2 and 4 (each within the scatter of the next); then compound 1.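

Replacing 1,2-dihydroxyethyl with 2,2-dimethyl-1,3-dioxolan-4-yl on a saturated chain carbon bound to an aromatic nitrogen gives, in this assay, an at least 4.3-fold lower number from compound 3 to compound 4 (0.63 log units; beyond the scatter), so this place accepts a larger group that carries a ring and has 0 hydrogen-bond donors. The value of compound 3 is a limit of the assay and not a number: the limit of > 1000 nM in this assay, at which 1 of the 4 values shown sits. The new group also shows that hydrogen-bond donors on this side chain are not required for a low number among these compounds, since the result includes a 1.5-fold higher number from compound 2 to compound 4 (0.19 log units; within the scatter) and a 5.8-fold lower number from compound 1 to compound 4 (0.77 log units; beyond the scatter).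

The compounds shown change the ring, the two added methyl groups and the two hydroxy groups together, and they do not separate the share of each in the step. From the compounds shown here alone, it also remains open how an amine, a carboxylic acid or a longer chain at this place would read in this assay, and whether a 1,3-dioxolane without the two methyl groups would keep the low number of compound 4.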